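Chlorophenyl Swap on a Triazole-Linked Sulfonamide Series

The compounds below may be only part of what the source reports. "The series", "measured", "known", "first", "only" and "open" are said of these compounds alone.

Compound 1, `O=c1[nH]cc(S(=O)(=O)Nc2ccccc2-c2cn(-c3ccc(F)cc3)nn2)c(=O)[nH]1`: > 20000 nM
Compound 2, `O=c1[nH]cc(S(=O)(=O)Nc2ccccc2-c2cn(-c3ccccc3Cl)nn2)c(=O)[nH]1`: 2240 nM
Compound 3, `O=c1[nH]cc(S(=O)(=O)Nc2cccc(-c3cn(-c4ccc(F)cc4)nn3)c2)c(=O)[nH]1`: > 20000 nM

Of the compounds shown here, three have been measured in a functional assay on HepG2 cells (Homo sapiens) for antiproliferative activity, read by MTT assay, with a stated time of 24 h; on this read-out lower numbers stand for stronger inhibition and higher numbers for weaker inhibition. For compound 1 the value > 20000 nM is a limit of the assay, not a number. Compound 2 gives 2240 nM; the change 2-chlorophenyl in place of 4-fluorophenyl on an aromatic nitrogen produced an at least 8.9-fold lower number from compound 1 to compound 2 (0.95 log units; beyond the scatter). For compound 3 the value > 20000 nM is also a limit. Of the measured values, (the limit of > 20000 nM in this assay, at which 2 of the 3 values shown sit). How the core of compound 3 differs from that of compound 1 is not broken down here.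

Compound 4, `O=c1[nH]cc(S(=O)(=O)Nc2cccc(-c3cn(-c4ccccc4Cl)nn3)c2)c(=O)[nH]1`, carries the same change applied to compound 3: 2-chlorophenyl in place of 4-fluorophenyl on an aromatic nitrogen. The place is the same in both cases. Compound 4 is expected to give 6000 nM, between 1500 nM and 20000 nM, which would mean an expected step of an at least 3.3-fold lower number from compound 3 to compound 4 (0.52 log units; beyond the scatter), resting on the fact that this change produced an at least 8.9-fold lower number from compound 1 to compound 2 (0.95 log units; beyond the scatter).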

Compound 4, half-maximal inhibitory concentration: 4030 nM
The estimate for compound 4 lay 1.5-fold (0.17 log units) above the measured number; measured number inside the range.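

In this assay, 2-chlorophenyl in place of 4-fluorophenyl again lowered the number on the second core, with an at least 4.9-fold lower number from compound 3 to compound 4 (0.69 log units; beyond the scatter). Set beside the earlier step, the result on the two cores reads: the same change on two cores in this assay, an at least 8.9-fold lower number (0.95 log units; beyond the scatter) from compound 1 to compound 2 and an at least 4.9-fold lower number (0.69 log units; beyond the scatter) from compound 3 to compound 4; the limit leaves it open whether they differ. This shows that the direction of the change held on both cores, but not that its size carried over or that it would hold on any other core, as the starting values of compound 1 and compound 3 are both limits: the limit of > 20000 nM in this assay, at which 2 of the 4 values shown sit.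

The compounds shown leave open whether the step follows the chlorine or its place on the ring, which a 4-chlorophenyl or 2-fluorophenyl group could separate. Also open, from the compounds shown here alone, is how an unsubstituted phenyl or a methoxyphenyl group would behave.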